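Acid to ethyl amide on the pendant ring: compound 3

The source may report more compounds than this note shows. Statements on the series, on what has been measured and on what is new or still open speak of the compounds shown alone.

Measured so far in a functional assay on PC-3 cells (Homo sapiens) for cytotoxicity, read by MTT assay, with a stated time of 96 h; a lower number here means a stronger inhibitor, a higher number a weaker inhibitor:
compound 1 `O=[N+]([O-])c1ccc2nc(CNc3ccccc3)cnc2c1`: 56000 nM
compound 2 `O=C(O)c1ccc(NCc2cnc3cc([N+](=O)[O-])ccc3n2)cc1`: 45000 nM

Compound 2 stands on the lower of the two numbers, but the step from its neighbour, a 1.2-fold lower number from compound 1 to compound 2 (0.09 log units; within the scatter), lies within the scatter, so the two compounds cannot be ranked against each other. Both are weak in this assay.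

Compound 3 `CCNC(=O)c1ccc(NCc2cnc3cc([N+](=O)[O-])ccc3n2)cc1` is the next variation. The change from compound 2 is ethylamino in place of hydroxy on a carbonyl carbon; cut one bond further out it reads carboxy to ethylcarbamoyl.

Going by the values given here, the only measured step, a 1.2-fold lower number from compound 1 to compound 2 (0.09 log units; within the scatter), places a carboxy group where compound 1 has hydrogen and moves the number by less than the scatter. It bears on compound 3 only loosely: it shows that the site tolerates a carboxy group without a shift, but nothing here tests what the acid itself contributes or what an amide at the same carbonyl carbon does. Among the compounds with values here, with no measured step acting on the carbonyl substituent, the expectation is a step of no size beyond the scatter in this assay.

Compound 3 is therefore expected to give about 40000 nM, within a range of 15000 nM to 110000 nM. That estimate corresponds to a step of a 1.1-fold lower number from compound 2 to compound 3 (0.05 log units; within the scatter), which is expected to fall inside the usual scatter.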

Compound 3, half-maximal inhibitory concentration: 66000 nM
Compound 3: the middle estimate sits 1.7-fold (0.22 log units) below what was measured; measured number inside the range.
By their numbers in this assay, from the lowest: compounds 2, 1 and 3 (each within the scatter of the next).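

In this assay, going by these compounds alone, ethylamino in place of hydroxy on the carbonyl carbon gives a 1.5-fold higher number from compound 2 to compound 3 (0.17 log units; within the scatter), the first reading of a change at this carbonyl carbon itself, and the step stays within the scatter. Measured against the unsubstituted pendant ring, the ethyl amide gives a 1.2-fold higher number from compound 1 to compound 3 (0.07 log units; within the scatter), also within the scatter, so neither the acid nor the ethyl amide separates from compound 1 and the three compounds cannot be ranked. No accompanying measurement bears on these steps, so no explanation for them can be offered.

Going by these compounds, it remains open whether any group on this carbonyl carbon can move the number beyond the scatter, for example a longer chain such as butylamino, a cyclic amine such as morpholine, or the methoxy of a methyl ester. Also open, on these data alone, is whether the pendant ring is a productive place for change at all, since the nitro group on the shared core stays the same in all three compounds and replacing it, for instance with an amine or a nitrile, would test the other end of the series.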